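The source may hold more compounds than are shown below. What is called first, only, known or untested is meant among the compounds shown, and "the series" means these compounds.

Compound 1 `c1ccc(-c2cn3ccnc3c(-c3ccc4ncn(C5CCCCC5)c4c3)n2)cc1` is the starting point of this small series. In a functional assay on LOX IMVI cells (Homo sapiens) for inhibition, read by sulforhodamine B assay, with a stated time of 48 h, tested at 10 uM (a higher number here means more inhibition at the concentration tested (going by the name of the read-out), a lower number less inhibition), compound 1 gives 39.6%. Compound 2 `Fc1ccc(-c2cn3ccnc3c(-c3ccc4ncn(C5CCCCC5)c4c3)n2)cc1` carries a fluoro where compound 1 has hydrogen, and in this assay compound 2 gives 3.5%. That single change produced a number 36.1 percentage points lower from compound 1 to compound 2 (beyond the scatter). Compound 2 therefore stands at the bottom of the two measured numbers, well apart from compound 1.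

Compound 3 `CC(=O)c1ccc(-c2cn3ccnc3c(-c3ccc4ncn(C5CCCCC5)c4c3)n2)cc1` differs from compound 2 only in this way: acetyl in place of fluoro on an aromatic carbon. Within the data shown here, the one measured step that bears on it is the change at this same position from compound 1 to compound 2, which was large and downward. Among the measured compounds shown here, no measured step tells what an acetyl does here, so the expectation rests on compound 2 sitting at the low end: there is little room for the number to fall further, while a return toward compound 1 remains possible. For compound 3 the estimated step is a number 16.5 percentage points higher from compound 2 to compound 3 (beyond the scatter). The estimate for compound 3 in this assay is 20%, with a range from 0% to 50%.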

Compound 3, a percentage reported as inhibition, at one concentration (the size of the read-out at that concentration, not a potency): 14.5%
Compound 3: the middle estimate sits 5.5 percentage points above what was measured, and the stated range covers the measured number.
By their numbers in this assay, from the lowest: compound 2; then compound 3; then compound 1.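

Replacing fluoro with acetyl gives a number 11 percentage points higher from compound 2 to compound 3 (beyond the scatter) in this assay, so the low reading of compound 2 does not apply to every group placed on this carbon, para to a large group: the outcome depends on which group stands there. Acetyl still gives a number 25.1 percentage points lower from compound 1 to compound 3 (beyond the scatter), so both groups shown at this place read lower than the plain hydrogen of compound 1, and a second substituent now shares that downward direction. No supporting information is available to explain why acetyl and fluoro differ here.

From the compounds shown here alone, it remains open whether another group at this place, such as an amine, a carboxylic acid or a longer chain, would match or exceed the hydrogen of compound 1, or whether every addition here lowers the reading to some degree. Going by these compounds, it is also open whether the difference between compound 2 and compound 3 tracks the extra heavy atoms of acetyl or its hydrogen-bond acceptor, since the two arrive together in this one change.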